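A few compounds are considered here, and "the series" means these few. Any claim that something is new, unique, unknown or untested is made for them only; others in the source may bear on it.

Measured so far:
compound 1, `COC(=O)c1ccc(CN2CCC[C@H](O[C@H](CO)c3cc(Cl)cc(Cl)c3)[C@@H]2c2ccccc2)c(C)c1`, giving > 200000 nM;
compound 2, `Cc1cc(C(=O)O)ccc1CN1CCC[C@@]2(C[C@@H](c3ccccc3)CO2)[C@@H]1c1ccccc1`, giving > 200000 nM.

Both numbers come from an assay on isolated protein for activation of cGMP-dependent protein kinase 1 (Homo sapiens), read by ADP-Glo, with stated times of 30 min and 2 h; a lower number here means that less compound is needed, a higher number that more compound is needed for the effect. For compound 1 the value > 200000 nM is a limit of the assay, not a measured number: no activation was seen up to the highest concentration tested. Compound 2 sits at the same kind of limit with > 200000 nM, so neither compound gives a usable number, and nothing can be said about an order between them. The whole picture rests on (the limit of > 200000 nM in this assay, at which 2 of the 2 values shown sit).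

Compound 3, `Nc1cc(C(=O)O)ccc1CN1CCC[C@H](O[C@H](CO)c2cc(Cl)cc(Cl)c2)[C@@H]1c1ccccc1`, has not been measured in this assay. It differs from compound 1 in one place, as follows: a group of 10 heavy atoms (7 carbon, 1 nitrogen, 2 oxygen; one six-membered aromatic ring of carbon only) in place of a group of 11 heavy atoms (9 carbon, 2 oxygen; one six-membered aromatic ring of carbon only), on a saturated chain carbon bound to an amine nitrogen in a ring. Going by the values given here, no step between measured compounds is available to judge what such a change does here, so any expectation rests on the two limits alone. With compound 1 at > 200000 nM, the most likely outcome is that compound 3 also reaches only the limit, and the step of an at least 1.3-fold lower number from compound 1 to compound 3 (0.12 log units; that floor lies within the scatter) is expected to stay within the scatter. The estimate for compound 3 is 150000 nM, with a range from 20000 nM to 400000 nM.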

Compound 3, half-maximal effective concentration: 168000 nM
Compound 3: middle estimate off by 1.1-fold (0.05 log units), on the low side; low and high end bracket the measured number.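

In this assay compound 3 gives 168000 nM, a real reading, so a group at this place, on a saturated chain carbon bound to an amine nitrogen in a ring, can give a number inside the range of the assay. Putting 2-amino-4-carboxyphenyl in place of the group of compound 1 gives an at least 1.1-fold lower number from compound 1 to compound 3 (0.07 log units; that floor lies within the scatter), and this figure is only a floor, so the true size of the step could be small or large. Compound 1 remains a limit of the assay with > 200000 nM, and the reading of the step stays tied to that limit: the limit of > 200000 nM in this assay, at which 2 of the 3 values shown sit.

The compounds shown leave open which part of 2-amino-4-carboxyphenyl matters here, since its amine and its carboxylic acid enter together and neither is seen alone on the shared core. From the compounds shown here alone, it is also open how a different group in the same place, such as a primary amide or a tetrazole, would read in this assay.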